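The compounds below may be only part of what the source reports. "The series", "measured", "known", "first", "only" and "open" are said of these compounds alone.

Measured so far in a functional assay on DU-145 cells (Homo sapiens) for inhibition, read by MTT assay, with a stated time of 72 h; a lower number here means a stronger inhibitor, a higher number a weaker inhibitor:
- compound 1, `O=C1C=C(N2CCN(c3ccccc3)CC2)C(=O)c2ccccc21`, gives 9900 nM
- compound 2, `O=C1C=C(N2CCN(c3ccccc3Cl)CC2)C(=O)c2ccccc21`, gives 2900 nM
- compound 3, `O=C1C=C(N2CCC(c3ccccc3)CC2)C(=O)c2c(O)cccc21`, gives 3000 nM

Compound 4, `O=C1C=C(N2CCC(c3ccc(Cl)cc3)CC2)C(=O)c2c(O)cccc21`, has not been measured. It differs from compound 3 by chloro in place of hydrogen on an aromatic carbon. The same kind of change is seen between compound 1 and compound 2, namely (chloro in place of hydrogen on an aromatic carbon), where the entering chloro sits ortho to a large group rather than para to it as in compound 4. That change gave a 3.4-fold lower number from compound 1 to compound 2 (0.53 log units; beyond the scatter). How the core of compound 3 differs from the core of compound 1 is not broken down here. Resting on that single step, a modest step is expected for compound 4: a 2.0-fold lower number from compound 3 to compound 4 (0.30 log units; within the scatter). Compound 4 is therefore estimated at 1500 nM, plausibly between 600 nM and 4500 nM.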

Compound 4, half-maximal inhibitory concentration: 2600 nM
Compound 4: the middle estimate sits 1.7-fold (0.24 log units) below what was measured; the measured number falls inside the stated range.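

In this assay, replacing phenyl with 4-chlorophenyl gives a 1.2-fold lower number from compound 3 to compound 4 (0.06 log units; within the scatter). Set beside the earlier step, the same swap of hydrogen for chloro did not carry over at the same size from one core to the other: the same change on two cores in this assay, a 3.4-fold lower number (0.53 log units; beyond the scatter) from compound 1 to compound 2 and a 1.2-fold lower number (0.06 log units; within the scatter) from compound 3 to compound 4, 3.0-fold (0.47 log units) apart, beyond the scatter of two such steps This does not show what sets the two steps apart, as the cores differ, the chloro sits para to a large group only in compound 4, and two steps are too few for a rule.

From the compounds shown here alone, it remains open whether chloro placed para to a large group on the core of compound 1 would give a step closer to the earlier one. Going by these compounds, it is also open whether a methoxy group or an amine at that place on the core of compound 3 would give a larger step than chloro.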